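A few compounds are considered here, and "the series" means these few. Any claim that something is new, unique, unknown or untested is made for them only; others in the source may bear on it.

Measured so far:
- compound 1 `CCOC(=O)c1c(C)coc1-c1ccc2c(CC)cccc2c1OC`: 3.9 ug/mL
- compound 2 `CCCOC(=O)c1c(C)coc1-c1ccc2c(CC)cccc2c1OC`: a limit, > 10 ug/mL
- compound 3 `CCc1cccc2c(OC)c(-c3occ(C)c3C(=O)On3nnc4ccccc43)ccc12`: a limit, > 10 ug/mL

All three share one core and differ only at the ester on the furan ring. In a functional assay on MDA-MB-231 cells (Homo sapiens) for cytotoxicity, read by MTT assay, with a stated time of 72 h (on this read-out lower numbers stand for an effect already at smaller amounts and higher numbers for an effect only at larger amounts of compound), compound 1 gives 3.9 ug/mL. For compound 2 only a limit is known, > 10 ug/mL. For compound 3 likewise only a limit is known, > 10 ug/mL. So compound 2 sits at the upper edge of what this assay reports, as stated in the limit of > 10 ug/mL in this assay, at which 2 of the 3 values shown sit.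

Compound 4 `CCc1cccc2c(OC)c(-c3occ(C)c3CO)ccc12` has not been measured. It differs from compound 2 by hydroxymethyl in place of propoxycarbonyl on an aromatic carbon, that is, the whole ester is removed and a small hydroxyl-bearing group takes its place.

Going by the values given here, two measured steps touch the same position: an at least 2.5-fold higher number from compound 1 to compound 2 (0.40 log units; beyond the scatter) and an at least 2.5-fold higher number from compound 1 to compound 3 (0.40 log units; beyond the scatter). Both lengthen or enlarge the ester and both push the number beyond the limit; the step that the two limits leave unreadable from compound 2 to compound 3 cannot be sized. Among the compounds with values here, no measured step shrinks the group, and because compound 2 sits at > 10 ug/mL, its step to compound 4 cannot be read precisely either. The expectation for compound 4 is therefore loose: a step of a number no higher from compound 2 to compound 4 (the limit leaves the size open), with compound 4 estimated at 10 ug/mL, between 3 ug/mL and 30 ug/mL.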

Compound 4, concentration for half-maximal effect: > 10 ug/mL
Compound 4 ended at the assay's limit (the forecaster's own chance of this, stated with the estimate: 55%); the middle value sits exactly at the limit.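

Going by these compounds alone, compound 4 is the first change at this position that makes the group smaller rather than larger, and putting hydroxymethyl in place of ethoxycarbonyl gives an at least 2.5-fold higher number from compound 1 to compound 4 (0.40 log units; beyond the scatter). So in this assay, moving away from ethoxycarbonyl in either direction, to a larger ester or to a much smaller group without a carbonyl, costs the readable value, and among these four compounds only compound 1 gives a number rather than a limit: the limit of > 10 ug/mL in this assay, at which 3 of the 4 values shown sit. Compound 4 has only a limit, > 10 ug/mL, and with limits on both sides its step from compound 2, like the step from compound 2 to compound 3, cannot be read.

On these data alone, how far compound 2, compound 3 and compound 4 lie past the limit, and whether they differ from one another at all, remains open. Also open, as far as these compounds go, is how narrow the requirement at this position is: whether a methyl ester, a carboxylic acid or a simple amide in place of ethoxycarbonyl would keep a readable value near that of compound 1.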